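Aryl swap at the ring nitrogen: outlook for compound 3

The source may hold more compounds than are shown below. What is called first, only, known or untested is meant among the compounds shown, and "the series" means these compounds.

Measured so far:
compound 1 `CCCCCCCCCCCCCCNc1nc(SCc2ccc(C(F)(F)F)cc2)nc2ccccc12` in a functional assay on MCF7 cells (Homo sapiens) for cytotoxicity, read by MTT assay, with a stated time of 72 h; a lower number here means a stronger inhibitor, a higher number a weaker inhibitor: > 50000 nM
compound 2 `FC(F)(F)c1ccc(CSc2nc(Nc3cccc(Cl)c3)c3ccccc3n2)cc1` in this assay: 25100 nM

The value for compound 1 is a limit of the assay, not a number. Among the compounds with values here, compound 2 therefore carries the only numerical value shown, and stands alone in it; the other entry is the limit of > 50000 nM in this assay, at which 1 of the 2 values shown sits.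

Compound 3 `COc1cc(Nc2nc(SCc3ccc(C(F)(F)F)cc3)nc3ccccc23)cc(OC)c1` differs from compound 2 by 3,5-dimethoxyphenyl in place of 3-chlorophenyl on a nitrogen on an aromatic ring. No measured step in the series bears on this change, so its size cannot be read from the numbers shown. The step of a 1.1-fold lower number from compound 2 to compound 3 (0.06 log units; within the scatter) is expected to stay within the scatter. Compound 3 is estimated in this assay at 22000 nM, between 6000 nM and 80000 nM.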

Compound 3, half-maximal inhibitory concentration: 6990 nM
Beside the measured number, compound 3's estimate is 3.1-fold (0.50 log units) above it, within the range that was stated.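

In this assay, within the data shown here, the group on the nitrogen now proves able to shift the read-out, with a 3.6-fold lower number from compound 2 to compound 3 (0.56 log units; beyond the scatter), the only step that can be read. That single step cannot separate the loss of the chlorine from the gain of the two methoxy groups, whose oxygens bring hydrogen-bond acceptors absent from 3-chlorophenyl. Compound 1 remains a limit, not a number: the limit of > 50000 nM in this assay, at which 1 of the 3 values shown sits.

Open, on these data alone, is whether a single methoxy group on the phenyl ring would suffice. Also open, as far as these compounds go, is how an amine or a carboxylic acid on that ring would read.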